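This account rests on a few compounds, and the source may have more. Where it says the series, first, only, none or still open, it means among the compounds named here.

Working notes on the series. In a functional assay on CHO cells for agonist activity at Free fatty acid receptor 1 (Homo sapiens), read by FLIPR and calcium flux, tested at 1 uM (on this read-out lower numbers stand for an effect already at smaller amounts and higher numbers for an effect only at larger amounts of compound), compound 3 `Cc1cccc(OCc2nnc(C(=O)Nc3ccc(CCC(=O)O)cc3)s2)c1` gives 3260 nM, the highest of the three numbers at hand; compound 1 `O=C(O)CCc1ccc(NC(=O)c2nnc(COc3ccc4c(c3)CCC4)s2)cc1` gives 1380 nM, and compound 2 `Cc1ccc(OCc2nnc(C(=O)Nc3ccc(CCC(=O)O)cc3)s2)cc1C` gives 1130 nM. Compound 4 `Cc1ccc(OCc2nnc(C(=O)Nc3ccc(CCC(=O)O)cc3)s2)cc1` differs from compound 3 by 4-methylphenyl in place of 3-methylphenyl on an oxygen on a saturated carbon, so it keeps one of the two methyls that compound 2 carries. Within the data shown here, two measured steps bear on this: a 2.9-fold higher number from compound 2 to compound 3 (0.46 log units; beyond the scatter) and a 2.4-fold higher number from compound 1 to compound 3 (0.37 log units; beyond the scatter), both modest and both leading from lower numbers up to compound 3. A single methyl on the phenyl is thus expected to give back part of that ground, and for compound 4 the expected step is a 2.0-fold lower number from compound 3 to compound 4 (0.31 log units; beyond the scatter), a modest move to a lower number. The estimate for compound 4 is 1600 nM, with a range of 700 nM to 3600 nM.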

Compound 4, half-maximal effective concentration: 2170 nM
Compound 4: middle estimate off by 1.4-fold (0.13 log units), on the low side; measured number inside the range.
By their numbers in this assay, from the lowest: compounds 2, 1, 4 and 3 (each within the scatter of the next, the first and the last beyond it).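

Placing the methyl as 4-methylphenyl in place of 3-methylphenyl, on the oxygen on a saturated carbon, does not separate the two compounds (with a 1.5-fold lower number from compound 3 to compound 4 (0.18 log units; within the scatter)). Compound 4, unlike compound 3, also stays within the scatter of the 3,4-dimethylphenyl and 2,3-dihydro-1H-inden-5-yl compounds (with a 1.9-fold higher number from compound 2 to compound 4 (0.28 log units; within the scatter) and a 1.6-fold higher number from compound 1 to compound 4 (0.20 log units; within the scatter)). Nothing at hand offers an explanation for these small steps.

Still open, on these data alone, is whether a methoxy group or a chlorine on this phenyl would move the number beyond the scatter. Also open, as far as these compounds go, is what a longer chain to the carboxylic acid would do.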